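The source may hold more compounds than are shown below. What is called first, only, known or untested is meant among the compounds shown, and "the series" means these compounds.

Compound 1 `COc1ccc(-c2cc(=O)c3c(OC)cc(OC)cc3n2S(=O)(=O)c2cc(F)c(F)c(F)c2)cc1` in an ADME assay on BJ cells (Homo sapiens) for antiproliferative activity, with a stated time of 72 h (a lower number here means that less compound is needed, a higher number that more compound is needed for the effect), gives only a limit of the assay, > 65500 nM. Compound 2 `COc1ccc(-c2cc(=O)c3c(OC)cc(OC)cc3n2S(=O)(=O)c2c(F)c(F)c(F)c(F)c2F)cc1` likewise gives only a limit in this assay, > 34400 nM. Compound 3 `COc1ccc(-c2cc(=O)c3c(OC)cc(OC)cc3n2S(=O)(=O)c2ccc(Br)cc2)cc1` also ends at a limit in this assay, > 86200 nM.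

Compound 3 therefore stands among three values that are all limits (the limit of > 34400 nM in this assay, at which 1 of the 3 values shown sits, (the limit of > 65500 nM in this assay, at which 1 of the 3 values shown sits), (the limit of > 86200 nM in this assay, at which 1 of the 3 values shown sits)), and none of them is a number. Compound 4 `COc1ccc(-c2cc(=O)c3c(OC)cc(OC)cc3n2S(=O)(=O)c2ccc(OC)cc2)cc1` differs from compound 3 by methoxy in place of bromo on an aromatic carbon. Among the compounds with values here, the steps that bear on changes at the same aryl sulfonyl are a step that the two limits leave unreadable from compound 1 to compound 3 and a step that the two limits leave unreadable from compound 2 to compound 3; neither has a readable size, so no direction beyond the scatter can be drawn from them. Compound 4 is expected at about 80000 nM, in a range from 20000 nM to 300000 nM. That estimate corresponds to an expected step of an at least 1.0-fold lower number from compound 3 to compound 4 (0.03 log units; that floor lies within the scatter).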

Compound 4, half-maximal effective concentration: > 82700 nM
Compound 4 gave a limit, no number; the forecaster's own chance of this, stated with the estimate: 80%; middle value at least 1.0-fold (0.01 log units) from the limit.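

Compound 4 also ends at a limit, so its steps to compound 1, compound 2 and compound 3 cannot be read in this assay. The compounds shown leave open how any of these aryl sulfonyl changes alters the effective concentration, since none gives a number.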